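Notes on the difluorophenyl cyclic urea amide series

The source may hold more compounds than are shown below. What is called first, only, known or untested is meant among the compounds shown, and "the series" means these compounds.

Measured so far:
compound 1 `N#Cc1cc(F)ccc1C1CCN(CCCNC(=O)C2=CNC(=O)N[C@@H]2c2ccc(F)c(F)c2)CC1` — 0.07 nM
compound 2 `CC1=C(C(=O)NCCCN2CCC(c3ccc(F)cc3C#N)CC2)[C@@H](c2ccc(F)c(F)c2)NC(=O)N1` — 0.17 nM
compound 3 `CC1=C(C(=O)NCCCN2CCC(c3ccc(F)cc3C#N)CC2)[C@@H](c2ccc(F)c(F)c2)NC(=O)N1C` — 0.12 nM

All three were tested in an assay on CHO cells with Alpha-1A adrenergic receptor (Homo sapiens) as the target; a higher number here means a weaker inhibitor, a lower number a stronger inhibitor. Compound 3 holds the second highest of the three numbers; the nearer neighbouring step is a 1.4-fold lower number from compound 2 to compound 3 (0.15 log units; within the scatter), and the gap between compound 3 and compound 1 is within the scatter as well, so the three compounds cannot be ranked against one another on these data.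

Compound 4 `CN1C=C(C(=O)NCCCN2CCC(c3ccc(F)cc3C#N)CC2)[C@@H](c2ccc(F)c(F)c2)NC1=O` is the next step from compound 3. The change is hydrogen in place of methyl on a double-bonded ring carbon. In substance this undoes the change seen between compound 1 and compound 2, where the step was a 2.4-fold higher number from compound 1 to compound 2 (0.39 log units; beyond the scatter), while keeping the methyl on the amide-type ring nitrogen that compound 3 carries; that latter methyl gave a 1.4-fold lower number from compound 2 to compound 3 (0.15 log units; within the scatter), within the scatter. Within the data shown here, the measured step that bears on compound 4 is therefore the one from compound 1 to compound 2, read in reverse, and a modest move to a lower number is expected, with the ring-nitrogen methyl adding little either way.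

Compound 4 is estimated at 0.06 nM in this assay, with a range of 0.03 nM to 0.12 nM, which corresponds to an expected step of a 2.0-fold lower number from compound 3 to compound 4 (0.30 log units; within the scatter).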

Compound 4, inhibition constant: 0.068 nM
The estimate for compound 4 lay 1.1-fold (0.05 log units) below the measured number; low and high end bracket the measured number.
By their numbers in this assay, from the lowest: compounds 4, 1, 3 and 2 (each within the scatter of the next, the first and the last beyond it).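

Working from this assay, hydrogen in place of methyl on the double-bonded ring carbon can now be read on a second core, the one carrying the methyl on the ring nitrogen, and there the step is a 1.8-fold lower number from compound 3 to compound 4 (0.25 log units; within the scatter). The two readings of this change do not differ beyond the scatter, while only the first of them clears it: the same change on two cores in this assay, a 2.4-fold higher number (0.39 log units; beyond the scatter) from compound 1 to compound 2 and a 1.8-fold higher number (0.25 log units; within the scatter) from compound 4 to compound 3, 1.4-fold (0.14 log units) apart, within the scatter of two such steps. The methyl on the amide-type ring nitrogen can also now be read on the core without the carbon methyl, where the step is a 1.0-fold lower number from compound 1 to compound 4 (0.01 log units; within the scatter), so this methyl shows no change on either core: the same change on two cores in this assay, a 1.4-fold lower number (0.15 log units; within the scatter) from compound 2 to compound 3 and a 1.0-fold lower number (0.01 log units; within the scatter) from compound 1 to compound 4, 1.4-fold (0.14 log units) apart, within the scatter of two such steps.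

As far as these compounds go, only hydrogen and methyl are represented on the double-bonded ring carbon and the ring nitrogen, so it remains open whether a larger group there, such as ethyl or aminomethyl, would keep the numbers in this assay in this range. All four compounds also share the 3,4-difluorophenyl group and the same chain to the piperidine, so these steps may not carry over to a core with a longer chain or a different aryl group.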